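Metabolic stability across a sulfonylbenzamide series: compound 4 estimate

A few compounds are considered here, and "the series" means these few. Any claim that something is new, unique, unknown or untested is made for them only; others in the source may bear on it.

Measured so far:
compound 1, `CC(C)(C)NC(=O)NCCS(=O)(=O)NC(=O)c1ccc(Nc2nc(NC3(c4ccc(Cl)cc4)CC3)nc(OCC(F)(F)F)n2)cc1`, 96%
compound 2, `O=C(NS(=O)(=O)CCNC(=O)C1CC1)c1ccc(Nc2nc(NC3(c4ccc(Cl)cc4)CC3)nc(OCC(F)(F)F)n2)cc1`, 90%
compound 3, `COC(=O)NCCS(=O)(=O)NC(=O)c1ccc(Nc2nc(NC3(c4ccc(Cl)cc4)CC3)nc(OCC(F)(F)F)n2)cc1`, 90%

All three were run in an ADME assay on microsomes from liver (Homo sapiens) for metabolic stability, with a stated time of 10 min; on this read-out lower numbers stand for a less stable compound and higher numbers for a more stable compound. Compound 3 stands level with compound 2 at the digits shown, the two together being the lowest of the three numbers; its nearest neighbour is compound 2 with no change at the digits printed from compound 2 to compound 3 (within the scatter), and the furthest is compound 1, which lies above it by a number 6 percentage points lower from compound 1 to compound 3 (within the scatter). Every spread within the set is within the scatter.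

Compound 4, `NCCS(=O)(=O)NC(=O)c1ccc(Nc2nc(NC3(c4ccc(Cl)cc4)CC3)nc(OCC(F)(F)F)n2)cc1`, differs from compound 3 by hydrogen in place of methoxycarbonyl on an amine nitrogen. The measured steps that come nearest to this are a number 6 percentage points lower from compound 1 to compound 2 (within the scatter), a number 6 percentage points lower from compound 1 to compound 3 (within the scatter) and no change at the digits printed from compound 2 to compound 3 (within the scatter), each of which exchanges one group for another on the carbonyl carbon and each of which stays within the scatter. For the measured compounds named here, none of them removes the methoxycarbonyl altogether, so the step to compound 4 has no exact precedent in the set. Given that every exchange at this position so far has left this assay unmoved, compound 4 is expected to show no step beyond the scatter, a number 3 percentage points lower from compound 3 to compound 4 (within the scatter). Compound 4 is therefore estimated at 87%, with a range of 72% to 97%.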

Compound 4, percent of the compound remaining: 100%
Beside the measured number, compound 4's estimate is 13 percentage points below it, outside the stated range (above it).
By their numbers in this assay, from the lowest: compounds 2, 3, 1 and 4 (each within the scatter of the next).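

Working notes on the amine nitrogen of the 2-aminoethyl chain: earlier compounds only exchanged one group for another on the carbonyl carbon, whereas compound 4 removes the carbonyl-bearing group from the nitrogen altogether and leaves the free amino group. In this assay that removal reads a number 10 percentage points higher from compound 3 to compound 4 (within the scatter) for methoxycarbonyl, a number 10 percentage points higher from compound 2 to compound 4 (within the scatter) for cyclopropylcarbonyl and a number 4 percentage points higher from compound 1 to compound 4 (within the scatter) for (tert-butyl)carbamoyl, so with all four compounds within the scatter of one another, this read-out shows no need for any of these groups on the nitrogen, and compound 4 gives 100% on the same footing as the rest. Nothing at hand offers a reason for these numbers, and none is given here.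

From the compounds shown here alone, what stays open is whether the flat picture survives larger edits at this end of the molecule, such as a carboxylic acid in place of the amino group, a dimethylamino group on the same carbon, or a chain longer than 2-aminoethyl. For the compounds shown here, since no pair in the set lies beyond the scatter, the series so far marks no group at this position that separates one compound from another in this assay at all.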